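Thiadiazole amides: tert-butyl exchanged for ethoxy

The source may report more compounds than this note shows. Statements on the series, on what has been measured and on what is new or still open speak of the compounds shown alone.

Values in a functional assay on the whole organism (integument) for inhibition, with Chilo suppressalis as the target, read by scintillation counting, with a stated time of 72 h; a higher number here means a weaker inhibitor, a lower number a stronger inhibitor:

compound 1 `O=C(Nc1nnc(-c2ccc(Cl)cc2)s1)c1c(F)cccc1F`: > 5010 nM, a limit of the assay
compound 2 `O=C(Nc1nnc(-c2ccc(Cl)cc2)s1)c1c(Cl)cccc1Cl`: 380 nM
compound 3 `COc1cccc(OC)c1C(=O)Nc1nnc(-c2ccc(C(C)(C)C)cc2)s1`: 912 nM

Compound 1 sits at a limit of this assay and gives no number (the limit of > 5010 nM in this assay, at which 1 of the 3 values shown sits). Among the two numbers that are known, compound 3 holds the highest; the nearest is compound 2, whose number is lower by a margin beyond the usual scatter. Compound 4 `CCOc1ccc(-c2nnc(NC(=O)c3c(OC)cccc3OC)s2)cc1` is not yet measured in this assay. It differs from compound 3 in one place: ethoxy in place of tert-butyl on an aromatic carbon. Among the compounds with values here, no pair of measured compounds shows what such an exchange does, so there is nothing in the data to weigh. For compound 4 the step from compound 3 is therefore expected to stay within the scatter of repeated measurement, with no direction assigned, a 1.1-fold higher number from compound 3 to compound 4 (0.04 log units; within the scatter). The estimate for compound 4 in this assay is 1000 nM, with a range from 300 nM to 3500 nM, and a real chance that only a limit is reported.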

Compound 4, half-maximal inhibitory concentration: 646 nM
Beside the measured number, compound 4's estimate is 1.5-fold (0.19 log units) above it, and the stated range covers the measured number.
By their numbers in this assay, from the lowest: compounds 2, 4 and 3 (each within the scatter of the next, the first and the last beyond it). At a limit, above all of these: compound 1.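

In this assay, within the data shown here, the exchange of tert-butyl for ethoxy on this aromatic carbon, para to a large group, gives a 1.4-fold lower number from compound 3 to compound 4 (0.15 log units; within the scatter) and is the first one-place comparison. Compound 3 and compound 4 therefore cannot be told apart at this position, although the counts differ by one hydrogen-bond acceptor and one heavy atom. Nothing among the measurements shown bears on a cause for this result.

Compound 2 differs from compound 3 and from compound 4 in more than one place, so the contribution of its chlorine atoms cannot be separated from that of the substituent at this position. On these data alone, how this assay responds at this position to an amine, a carboxylic acid or a longer alkoxy chain such as butoxy remains open.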